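Replacing a Carboxylic Acid Tail with a Nitrogen-Rich Ring

The compounds below may be only part of what the source reports. "The series", "measured", "known", "first", "only" and "open" are said of these compounds alone.

Of the compounds shown here, three sharing one core have been measured in a functional assay on CHO cells for antagonist activity at Glucagon receptor (Homo sapiens), read by cAMP accumulation, with stated times of 30 min and 45 min; on this read-out higher numbers stand for weaker inhibition and lower numbers for stronger inhibition. Compound 2, `CC(C)(C)CC[C@H](c1ccc(C(=O)NCCS(=O)(=O)O)cc1)N1C(=O)C(c2cc(Cl)cc(Cl)c2)=N[C@]12CC[C@@H](C(C)(C)C)CC2`, gives 8500 nM. Compound 3, `CC(C)(C)CC[C@H](c1ccc(C(=O)NCCCC(=O)O)cc1)N1C(=O)C(c2cc(Cl)cc(Cl)c2)=N[C@]12CC[C@@H](C(C)(C)C)CC2`, gives 350 nM. Compound 1, `CCCCC[C@H](c1ccc(C(=O)NCc2nn[nH]n2)cc1)N1C(=O)C(c2cc(Cl)cc(Cl)c2)=N[C@]12CC[C@@H](C(C)(C)C)CC2`, gives 130 nM. Compound 3 therefore stands second highest of the three numbers, above compound 1 and well below compound 2.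

Among the measured compounds shown here, the single measured step with one structural change is a 24-fold lower number from compound 2 to compound 3 (1.39 log units; beyond the scatter), which shows how strongly this tail position can move the read-out.

Compound 4, `CC(C)(C)CC[C@H](c1ccc(C(=O)NCCC2=NNNN2)cc1)N1C(=O)C(c2cc(Cl)cc(Cl)c2)=N[C@]12CC[C@@H](C(C)(C)C)CC2`, has not been measured. It differs from compound 3 by a group of 5 heavy atoms (1 carbon, 4 nitrogen; one five-membered non-aromatic ring with 4 hetero atoms) in place of a group of 4 heavy atoms (2 carbon, 2 oxygen; no ring), on a saturated chain carbon, two bonds along the chain from an amide-type nitrogen. For the measured compounds named here, no measured step covers this exact exchange. Going by the values given here, compound 1 carries a ring of the same kind at the tail but also a different alkyl chain, so it differs from compound 3 in more than one place and no step between them is computed; its value only shows that such a ring is compatible with a number near that of compound 3.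

Since the tail exchange in compound 4 leaves the rest unchanged and compound 1 gives 130 nM, a modest change is expected: the step of a 1.8-fold lower number from compound 3 to compound 4 (0.24 log units; within the scatter) is estimated, with compound 4 expected at 200 nM, within a range of 60 nM to 700 nM in this assay.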

Compound 4, half-maximal inhibitory concentration: 890 nM
Compound 4: middle estimate off by 4.5-fold (0.65 log units), on the low side; measured number outside the range, above it.
By their numbers in this assay, from the lowest: compound 1; then compound 3; then compound 4; then compound 2.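

Compound 4 gives the first direct test of the four-nitrogen ring at this place, on a saturated chain carbon, two bonds along the chain from an amide-type nitrogen, and in this assay the exchange for carboxymethyl brings a 2.5-fold higher number from compound 3 to compound 4 (0.41 log units; beyond the scatter) rather than a match within the scatter. The same ring compares far better with the sulfo tail, with a 9.6-fold lower number from compound 2 to compound 4 (0.98 log units; beyond the scatter) as the step, so the three tails on this core now fall in a clear order, with carboxymethyl giving the strongest inhibition, the ring coming next and sulfo giving the weakest. Position and tail together therefore do more than separate one poor group from the rest, yet nothing measured here explains why these groups rank as they do.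

As far as these compounds go, compound 1 differs from compound 3 in both its alkyl chain and its tail, so the share of each change in its number stays unknown, and pairing its chain with the tail of compound 4 would settle that. From the compounds shown here alone, how an amine or a primary amide would read at this place, and how a longer chain carrying the same ring would read, also remains open.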